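A few compounds are considered here, and "the series" means these few. Any claim that something is new, unique, unknown or untested is made for them only; others in the source may bear on it.

Measured so far:
compound 1, `COc1ccccc1/C=C/C(=O)/C=C/c1ccc(OCc2cn(CCCCOc3cc(=O)oc4ccccc34)nn2)c(OC)c1`, 43%
compound 2, `COc1cc(/C=C/C(=O)/C=C/c2cc(OC)c(OC)c(OC)c2)ccc1OCc1cn(CCCOc2cc(=O)oc3ccccc23)nn1`, 76%

Of the compounds shown here, two have been measured in a functional assay on HCT-116 cells (Homo sapiens) for inhibition, read by sulforhodamine B assay, with a stated time of 48 h, tested at 50 uM; a lower number here means less inhibition of growth, a higher number more inhibition of growth at the concentration tested. Compound 1 gives 43%, and compound 2 gives 76%. Compound 1 therefore stands at the lower of the two numbers, and compound 2 lies higher by a margin beyond the usual scatter. The two compounds differ in more than one place, so that gap cannot be tied to any single change.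

Compound 3, `COc1cc(/C=C/C(=O)/C=C/c2ccco2)ccc1OCc1cn(CCCCOc2cc(=O)oc3ccccc23)nn1`, has not yet been measured in this assay. It differs from compound 1 in one place only: furan-2-yl in place of 2-methoxyphenyl on a double-bonded chain carbon bound to a double-bonded chain carbon. Going by the values given here, no pair of measured compounds shows this particular change, so there is no direct guide to its effect, and the measured gap between compound 1 and compound 2 says nothing about it.

With nothing to build on, the expectation is a small step at most. Compound 3 is estimated to give 40%, within a range from 20% to 65%. This estimate means an expected step of a number 3 percentage points lower from compound 1 to compound 3 (within the scatter), not clearly beyond the usual scatter in either direction.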

Compound 3, percent growth inhibition at one concentration: 47%
Compound 3: middle estimate off by 7 percentage points, on the low side, and the stated range covers the measured number.
By their numbers in this assay, from the lowest: compounds 1 and 3 (each within the scatter of the next); then compound 2.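

In this assay, going by these compounds alone, furan-2-yl in place of 2-methoxyphenyl on a double-bonded chain carbon bound to a double-bonded chain carbon gives a number 4 percentage points higher from compound 1 to compound 3 (within the scatter) in the only pair of compounds here that differ in one place. For this pair, then, a six-membered aromatic ring of carbon only, in a group of 8 heavy atoms, can be exchanged for a five-membered aromatic ring with 1 hetero atom, in a group of 5 heavy atoms, with no change beyond the usual scatter of the assay. Nothing measured here shows why the two groups give such close numbers.

Going by these compounds, it remains open whether another group at this place, such as a pyridine ring or a phenyl ring carrying an amine, would move the number beyond the scatter. Compound 2, at 76%, differs from compound 1 in more than one place, so what lies behind its higher number also remains open, and a single change at a time would be needed to separate those differences.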